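Phenyl in place of dimethylamino on the core of compound 1

The compounds below may be only part of what the source reports. "The series", "measured", "known", "first", "only" and "open" are said of these compounds alone.

Measured compounds:
- compound 1, `Cc1ccn2c(C(=O)c3sc(N)nc3N(C)C)cnc2c1`: 85%
- compound 2, `Cc1ccc2ncc(C(=O)c3sc(N)nc3N(C)C)n2c1`: 23%
- compound 3, `Cc1cccn2c(C(=O)c3sc(N)nc3-c3ccccc3)cnc12`: 20%

Of the compounds shown here, three have been tested in a functional assay on the whole organism (strain Sprague-Dawley) for inhibition, with Rattus norvegicus as the target, read by paw edema, with stated times of 1 h and 3 h, at a dose of 50 mg/kg by the oral route; on this read-out lower numbers stand for less inhibition and higher numbers for more inhibition at the one dose given (going by the name of the read-out). Compound 1 stands highest of the three numbers, and both other values lie beyond the scatter below it: compound 2, which keeps the dimethylamino group on a differently built core, gives 23%, and compound 3, which carries a phenyl group on yet another core, gives 20%. No pair among these three differs in a single place, so no step can be read directly from them.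

Compound 4, `Cc1ccn2c(C(=O)c3sc(N)nc3-c3ccccc3)cnc2c1`, keeps the core of compound 1 and differs from it in one place only: phenyl in place of dimethylamino on an aromatic carbon. Going by the values given here, the only measured compound bearing a phenyl at this place is compound 3, and its low value comes with a different core, so it cannot settle the size of the step on its own. Still, a drop beyond the scatter is expected for compound 4, because compound 3 gives 20% with the same group in place. The expected step is a number 45 percentage points lower from compound 1 to compound 4 (beyond the scatter). Compound 4 is therefore estimated at 40% in this assay, within a range from 10% to 75%.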

Compound 4, a percentage reported as inhibition, in the whole organism at one dose (the size of the read-out at that dose, not a potency): 26%
The estimate for compound 4 lay 14 percentage points above the measured number, and the stated range covers the measured number.
By their numbers in this assay, from the lowest: compounds 3, 2 and 4 (each within the scatter of the next); then compound 1.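

On the core of compound 1, the position next to the ring nitrogen proves sensitive in this assay: with phenyl in place of dimethylamino on this aromatic carbon, the read-out comes out as a number 59 percentage points lower from compound 1 to compound 4 (beyond the scatter) at the one oral dose given. Going by these compounds alone, this is the first direct reading at this place, and it shows that the high value of compound 1 does not come from the core alone but depends on the group held here. The exchange replaces a non-ring group with one hydrogen-bond acceptor by a six-membered aromatic ring of carbon only, but nothing shown separates these differences or explains the loss in the read-out.

Going by these compounds, whether another amine such as morpholine or pyrrolidine, or a small group such as methyl, would keep the read-out at this carbon stays open. No other step among these compounds can be read, so it also remains open whether the same exchange would cost as much on a different core.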